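Shortening the hydroxyalkyl chain on a triazole-bearing quinoline

A few compounds are considered here, and "the series" means these few. Any claim that something is new, unique, unknown or untested is made for them only; others in the source may bear on it.

Of the compounds shown here, two sharing one core have been measured in an ADME assay on HEK293 cells (Homo sapiens) for cytotoxicity, read by sulforhodamine B assay, with a stated time of 48 h, tested at 10 uM; a higher number here means more inhibition at the concentration tested (going by the name of the read-out), a lower number less inhibition. Compound 1 `CCCCCCc1cn(C(c2ccccc2)c2cc3cc(Br)ccc3nc2OC)nn1` gives -3.17% in this assay. Within the data shown here, compound 2 `COc1nc2ccc(Br)cc2cc1C(c1ccccc1)n1cc(CCCO)nn1` gives 27.4% in this assay, the higher of the two numbers; the step of a number 30.6 percentage points higher from compound 1 to compound 2 (beyond the scatter) is the only measured step and separates the pair beyond the scatter. Compound 3 `COc1nc2ccc(Br)cc2cc1C(c1ccccc1)n1cc(CCO)nn1` is the next candidate and has not been measured. It differs from compound 2 as follows: hydroxy in place of hydroxymethyl on a saturated chain carbon, two bonds along the chain from an aromatic carbon. Among the measured compounds shown here, no measured step concerns this change; the one step known, from compound 1 to compound 2, replaces a propyl with hydroxy and so speaks to the presence of the hydroxy group, not to the length of the chain carrying it. Since compound 3 keeps the hydroxy group that compound 2 carries, the account expects a step of a number 5.4 percentage points lower from compound 2 to compound 3 (within the scatter) that stays within the scatter of this assay, with no direction favoured. For compound 3 the estimate in this assay is therefore 22%, within a range from 5% to 40%.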

Compound 3, a percentage reported as inhibition, at one concentration (the size of the read-out at that concentration, not a potency): 4.54%
Compound 3: the middle estimate sits 17.5 percentage points above what was measured; measured number outside the range, below it.
By their numbers in this assay, from the lowest: compounds 1 and 3 (each within the scatter of the next); then compound 2.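

In this assay the step from 3-hydroxypropyl to 2-hydroxyethyl is not a silent one: a number 22.9 percentage points lower from compound 2 to compound 3 (beyond the scatter) shows that at this position, on a saturated chain carbon two bonds along the chain from an aromatic carbon, the length of the chain carrying the hydroxy group counts, something the earlier step could not show. The hydroxy group alone therefore does not account for the higher number of compound 2, since a number 7.7 percentage points higher from compound 1 to compound 3 (within the scatter) places compound 3, which keeps that group, within the scatter of compound 1, which lacks it. No independent evidence bears on why shortening the chain by this one carbon has this effect.

Among these compounds, with only two chain lengths carrying a hydroxy group, it remains open whether the number keeps rising with a longer chain such as 4-hydroxybutyl or whether 3-hydroxypropyl is a peak, and whether hydroxymethyl on the triazole would match 2-hydroxyethyl. Going by these compounds, it is equally open whether the effect belongs to the hydroxy group itself, or whether an amine or a carboxylic acid at the end of the same three-carbon chain would give a similar number.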